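The compounds below may be only part of what the source reports. "The series", "measured", "known", "first", "only" and "open" are said of these compounds alone.

Compound 1 `CC(=O)N(C)c1ccc2[nH]c(-c3n[nH]c4ccccc34)cc2n1` gives > 50000 nM in a functional assay on A549 cells (Homo sapiens) for antiproliferative activity, read by MTT assay, with a stated time of 72 h (a higher number here means a weaker inhibitor, a lower number a stronger inhibitor), which is a limit of the assay and not a number.
Compound 2 `CN(C(=O)c1ccccc1)c1ccc2[nH]c(-c3n[nH]c4ccccc34)cc2n1` gives 13800 nM in this assay.
Compound 3 `CN(c1ccc2[nH]c(-c3n[nH]c4ccccc34)cc2n1)S(=O)(=O)c1ccc(Br)cc1` gives 19700 nM in this assay.

Compound 3 holds the highest of the two numbers shown; its nearest neighbour is compound 2, with a 1.4-fold higher number from compound 2 to compound 3 (0.15 log units; within the scatter). Compound 4 `CN(c1ccc2[nH]c(-c3n[nH]c4ccccc34)cc2n1)S(=O)(=O)c1cccc([N+](=O)[O-])c1` differs from compound 3 by 3-nitrophenyl in place of 4-bromophenyl on a sulfonyl sulfur. For the measured compounds named here, no measured step alters a substituent on the sulfonyl aryl ring; the steps touching this part of the molecule are an at least 2.5-fold lower number from compound 1 to compound 3 (0.40 log units; beyond the scatter) and a 1.4-fold higher number from compound 2 to compound 3 (0.15 log units; within the scatter), each exchanging the whole group on the nitrogen. With the sulfonyl and the nitrogen retained, compound 4 is expected to show a 1.0-fold higher number from compound 3 to compound 4 (0.01 log units; within the scatter), no step beyond the scatter. Compound 4 is therefore estimated at 20000 nM, between 7000 nM and 50000 nM.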

Compound 4, half-maximal inhibitory concentration: 20100 nM
For compound 4 the middle estimate is 1.0-fold (0.00 log units) below the measured one; measured number inside the range.
By their numbers in this assay, from the lowest: compounds 2, 3 and 4 (each within the scatter of the next). At a limit, above all of these: compound 1.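

The earlier steps shown here exchanged the whole group on the nitrogen, whereas compound 4 alters only the aryl ring on the sulfonyl sulfur. In this assay this gives a 1.0-fold higher number from compound 3 to compound 4 (0.01 log units; within the scatter), so 3-nitrophenyl and 4-bromophenyl cannot be told apart at this place. No measurement shown accounts for this. From the compounds shown here alone, it remains open whether an amine or a carboxylic acid on this aryl ring would separate from these compounds by more than the scatter. Equally open, going by these compounds, is what a simple alkyl chain on the sulfonyl sulfur, in place of the aryl ring, would give.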